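A para-methyl anilide in a chloropyrazine urea series

A few compounds are considered here, and "the series" means these few. Any claim that something is new, unique, unknown or untested is made for them only; others in the source may bear on it.

Compound 1 `CCOc1ccc(NC(=O)Nc2cccc(CNc3nccnc3Cl)c2)cc1`: 9080 nM
Compound 2 `O=C(Nc1cccc(CNc2nccnc2Cl)c1)Nc1ccc(Cl)cc1Cl`: 5740 nM
Compound 3 `O=C(Nc1cccc(CNc2nccnc2Cl)c1)Nc1cccc2ccccc12`: > 40000 nM

Three ureas sharing the same core have been tested in a functional assay on T-24 cells (Homo sapiens) for antiproliferative activity, read by MTT assay, with a stated time of 48 h; on this read-out higher numbers stand for weaker inhibition and lower numbers for stronger inhibition. Compound 2 gives 5740 nM, the lowest of the two numbers recorded; compound 1 sits nearest at 9080 nM, and the two lie within the scatter of each other. For compound 3 this assay reports only a limit, > 40000 nM (the limit of > 40000 nM in this assay, at which 1 of the 3 values shown sits).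

The move from compound 2 to compound 4 `Cc1ccc(NC(=O)Nc2cccc(CNc3nccnc3Cl)c2)cc1` is 4-methylphenyl in place of 2,4-dichlorophenyl on an amide-type nitrogen. Among the measured compounds shown here, one measured step bears on it: a 1.6-fold lower number from compound 1 to compound 2 (0.20 log units; within the scatter). That step, which exchanges one para-substituted phenyl for the dichlorophenyl, did not move the number beyond the scatter, and compound 4 carries a para-substituted phenyl much like compound 1 does. The expectation in this assay is therefore a step in the direction of a somewhat higher number, of the same small size, not clearly beyond the scatter: a 1.5-fold higher number from compound 2 to compound 4 (0.17 log units; within the scatter). Compound 4 is thus estimated to give 8500 nM, with a range from 3000 nM to 25000 nM.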

Compound 4, half-maximal inhibitory concentration: 9820 nM
Compound 4: middle estimate off by 1.2-fold (0.06 log units), on the low side; the range from low to high includes it.
By their numbers in this assay, from the lowest: compounds 2, 1 and 4 (each within the scatter of the next). At a limit, above all of these: compound 3.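

In this assay, the direct exchange of 2,4-dichlorophenyl for 4-methylphenyl on the amide-type nitrogen gives a 1.7-fold higher number from compound 2 to compound 4 (0.23 log units; within the scatter), so the removal of both chlorines and the addition of a methyl group do not separate these two compounds. The new compound also allows a comparison of two groups on the same aromatic carbon, with methyl in place of ethoxy giving a 1.1-fold higher number from compound 1 to compound 4 (0.03 log units; within the scatter), and with all three steps among compound 1, compound 2 and compound 4 now printed as within the scatter, these three phenyl groups cannot be ranked in this assay. Nothing among the measurements shown gives a reason for these small steps.

Compound 3 gives only a limit, > 40000 nM, so it cannot be placed on the same scale as the other three compounds. Going by these compounds, it remains open whether an amine or a carboxylic acid on this phenyl ring, or a chain longer than ethoxy, would give a number that lies beyond the scatter of compound 1, compound 2 and compound 4.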